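A few compounds are considered here, and "the series" means these few. Any claim that something is new, unique, unknown or untested is made for them only; others in the source may bear on it.

Measured compounds in a functional assay on HeLa cells (Homo sapiens) for antiproliferative activity, read by MTT assay, with a stated time of 48 h; on this read-out higher numbers stand for weaker inhibition and lower numbers for stronger inhibition:
- compound 1 `O=Cc1cn(-c2ccccc2)nc1-c1ccc(Cl)cc1` gives 15500 nM
- compound 2 `Fc1ccc(-c2nn(-c3ccccc3)cc2-c2nc3cc(F)ccc3[nH]2)cc1` gives 1570 nM
- compound 3 `Fc1ccc(-c2nn(-c3ccccc3)cc2-c2nc3cc(C(F)(F)F)ccc3[nH]2)cc1` gives 3520 nM

Compound 1 stands highest of the three numbers; the numbers of compound 2 and compound 3 lie beyond the scatter below it. Among the compounds with values here, the single measured step, a 2.2-fold higher number from compound 2 to compound 3 (0.35 log units; beyond the scatter), concerns the substituent on the benzimidazole and does not touch the change considered here.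

Compound 4 `Clc1ccc(-c2nn(-c3ccccc3)cc2-c2nc3ccccc3[nH]2)cc1` differs from compound 1 by 1H-benzimidazol-2-yl in place of formyl on an aromatic carbon. Within the data shown here, no measured step covers this exchange directly. What the numbers do show is that compound 2 and compound 3, both bearing a 1H-benzimidazol-2-yl group, give lower numbers than compound 1 with its formyl group. Compound 4 is therefore expected to give a lower number than compound 1, a step of a 7.0-fold lower number from compound 1 to compound 4 (0.85 log units; beyond the scatter). The estimate for compound 4 in this assay is 2200 nM, with a range from 800 nM to 6500 nM.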

Compound 4, half-maximal inhibitory concentration: 1650 nM
The estimate for compound 4 lay 1.3-fold (0.12 log units) above the measured number; low and high end bracket the measured number.
By their numbers in this assay, from the lowest: compounds 2 and 4 (each within the scatter of the next); then compound 3; then compound 1.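

Within the data shown here, exchanging formyl for 1H-benzimidazol-2-yl on this aromatic carbon gives a 9.4-fold lower number from compound 1 to compound 4 (0.97 log units; beyond the scatter) in this assay with the rest of the core unchanged, the first reading of this exchange on its own. The lower number therefore belongs to this exchange alone. No supporting measurement shows which feature of the entering group carries the step.

Open, going by these compounds, is whether a carboxylic acid, a primary amide or a hydroxymethyl group on this carbon would give a comparable number. Also open, on these data alone, is whether the six-membered aromatic ring of the entering group is needed.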